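The compounds below may be only part of what the source reports. "The series", "measured", "known", "first", "only" and "open" are said of these compounds alone.

Measured so far in a functional assay on CCRF-CEM cells (Homo sapiens) for antiproliferative activity, read by cell counting, with a stated time of 2 days; on this read-out higher numbers stand for weaker inhibition and lower numbers for stronger inhibition
- compound 1 `COc1cc(C(=O)c2sc(N)nc2N)cc(OC)c1OC` gives 42000 nM
- compound 2 `CCCCN(C)c1nc(N)c(C(=O)c2cc(OC)c(OC)c(OC)c2)s1` gives 42000 nM

Compound 1 stands level with compound 2 on these numbers, and the two values match at the digits given. Compound 3 (`COc1cc(C(=O)c2sc(N3CCCC3)nc2N)cc(OC)c1OC`) has not yet been measured. It differs from compound 1 by one swap on the shared core (pyrrolidin-1-yl in place of amino on an aromatic carbon), with pyrrolidin-1-yl in place of amino on an aromatic carbon.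

Going by the values given here, only one measured step bears on this swap (no change at the digits printed from compound 1 to compound 2 (within the scatter)). That step put butyl(methyl)amino in place of amino on an aromatic carbon, and it stayed within the scatter. Among the compounds with values here, a single step is thin evidence, and no measured compound yet carries the pyrrolidin-1-yl ring, so a real shift in either direction remains possible. Even so, no change beyond the scatter is expected in this assay. The estimated change is a 1.2-fold lower number from compound 1 to compound 3 (0.08 log units; within the scatter) on this reasoning. Compound 3 is estimated at 35000 nM with an expected range of 8000 nM to 80000 nM around that figure.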

Compound 3, half-maximal inhibitory concentration: 320 nM
Compound 3: middle estimate off by 110-fold (2.04 log units), on the high side; the measured number lies below the stated range.
By their numbers in this assay, from the lowest: compound 3; then compounds 1 and 2 (each within the scatter of the next).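

In this assay, this aromatic carbon, next to the ring nitrogen and next to the ring sulfur, proves highly sensitive to the group it carries: pyrrolidin-1-yl in place of amino gives a 130-fold lower number from compound 1 to compound 3 (2.12 log units; beyond the scatter), a change the earlier pair gave no hint of. Pyrrolidin-1-yl in place of butyl(methyl)amino gives a 130-fold lower number from compound 2 to compound 3 (2.12 log units; beyond the scatter), so putting carbon groups on this nitrogen is not enough on its own: compound 2 carries two such groups as an open chain and stands level with compound 1 at the digits printed, while among these three compounds only compound 3, with its five-membered non-aromatic ring, reaches the much lower number. Nothing available here explains why this ring makes such a difference.

Going by these compounds, it remains open whether the step depends on ring size or on the ring itself, which piperidin-1-yl, morpholin-4-yl or a short open-chain group such as dimethylamino on the same carbon would help to separate. Also open, on these data alone, is whether the step would survive replacing the amino group that stays on the core, for instance with a methyl group.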